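The compounds below may be only part of what the source reports. "The series", "measured", "known", "first", "only" and "open" are said of these compounds alone.

Series notes. Compound 1 `O=C(CC(CC(=O)NC1Cc2ccccc2C1)c1ccc(Cl)cc1)NCCN1CCCCC1` carries the piperidin-1-yl group; in a functional assay on MGC-803 cells (Homo sapiens) for inhibition (on this read-out lower numbers stand for stronger inhibition and higher numbers for weaker inhibition), compound 1 gives 89100 nM. Compound 2 `O=C(CC(CC(=O)NC1Cc2ccccc2C1)c1ccc(Cl)cc1)NCCN1CCCC1` is its pyrrolidin-1-yl counterpart. In this assay compound 2 returns only the limit > 100000 nM. The change from compound 2 to compound 1 is piperidin-1-yl in place of pyrrolidin-1-yl on a saturated chain carbon, two bonds along the chain from an amide-type nitrogen and amounts to an at least 1.1-fold lower number from compound 2 to compound 1 (0.05 log units; that floor lies within the scatter); the read-out here is capped by the limit of > 100000 nM in this assay, at which 2 of the 3 values shown sit.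

Compound 3 `CCN(C(=O)CC(CC(=O)NCCN1CCCC1)c1ccccc1)C1Cc2ccccc2C1` has a different core from compound 2; the difference between the two cores is not broken down here. In this assay compound 3 also returns only the limit > 100000 nM.

Compound 4 `CCN(C(=O)CC(CC(=O)NCCN1CCCCC1)c1ccccc1)C1Cc2ccccc2C1` has not been measured. It differs from compound 3 by piperidin-1-yl in place of pyrrolidin-1-yl on a saturated chain carbon, two bonds along the chain from an amide-type nitrogen, the same change as from compound 2 to compound 1, at the same place. The earlier step, an at least 1.1-fold lower number from compound 2 to compound 1 (0.05 log units; that floor lies within the scatter), was small. Because compound 3 returns only the limit > 100000 nM, compound 4 is expected to show a number no higher from compound 3 to compound 4 (the limit leaves the size open), most likely again reported as a limit. The estimate for compound 4 is 100000 nM, with an expected range of 45000 nM to 300000 nM.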

Compound 4, half-maximal inhibitory concentration: > 100000 nM
Compound 4: no number, only a limit; the forecaster's own chance of this, stated with the estimate: 70%; the middle value sits exactly at the limit.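

In this assay compound 4 gives > 100000 nM which is a limit and not a number. Compound 3 also returns only a limit, so no step can be read from compound 3 to compound 4, because both sit at the same cap: the limit of > 100000 nM in this assay, at which 3 of the 4 values shown sit.

The compounds shown leave open what size, if any, the change from pyrrolidin-1-yl to piperidin-1-yl has on the core of compound 3.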